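The compounds below may be only part of what the source reports. "The series", "measured", "known", "first", "only" and "open" are said of these compounds alone.

For the measured compounds named here, in a functional assay on B16 cells (Mus musculus) for inhibition (on this read-out lower numbers stand for stronger inhibition and higher numbers for weaker inhibition), compound 1 (`COc1cc(/C=C/C(=O)c2cccc(NC(=O)c3ccco3)c2)ccc1O`) gives 5.46 ug/mL, and compound 2 (`COc1cc(/C=C/C(=O)c2cccc(NC(=O)c3ccc(Cl)cc3Cl)c2)ccc1O`) gives 12.8 ug/mL, the higher of the two numbers so far. The next compound, compound 3 (`CCCC(=O)Nc1cccc(C(=O)/C=C/c2ccc(O)c(OC)c2)c1`), changes the group on the carbonyl carbon of compound 2: propyl in place of 2,4-dichlorophenyl on a carbonyl carbon. Going by the values given here, the one measured step at this place is a 2.3-fold higher number from compound 1 to compound 2 (0.37 log units; beyond the scatter), modest and beyond the scatter. It shows that 2,4-dichlorophenyl on this carbonyl carbon gives a higher number than furan-2-yl does. Among the compounds with values here, no compound with propyl at this place has been measured, so that step is only indirect guidance. A small move towards a lower number is therefore expected, no larger than the measured step and possibly within the scatter. The estimated step is a 1.6-fold lower number from compound 2 to compound 3 (0.20 log units; within the scatter). For compound 3 the estimate is 8 ug/mL, with an expected range of 3.5 ug/mL to 18 ug/mL.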

Compound 3, half-maximal inhibitory concentration: 1.43 ug/mL
The estimate for compound 3 lay 5.6-fold (0.75 log units) above the measured number, and the stated range ends above it.
By their numbers in this assay, from the lowest: compound 3; then compound 1; then compound 2.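

Up to this point the carbonyl carbon had carried only ring groups, so the series could not show whether a ring was needed at this place. In this assay propyl, which has no ring, gives a 9.0-fold lower number from compound 2 to compound 3 (0.95 log units; beyond the scatter) and also a 3.8-fold lower number from compound 1 to compound 3 (0.58 log units; beyond the scatter), so a ring is not required here for the lowest number of the three, and both ring groups sit higher. No measurement at hand accounts for the size of these steps.

From the compounds shown here alone, whether the number keeps falling with a shorter chain such as ethyl or a longer one such as hexyl remains open. Cyclohexyl, a ring without aromatic character, would help separate the effect of having a ring from that of having an aromatic ring at this place.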